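A few compounds are considered here, and "the series" means these few. Any claim that something is new, unique, unknown or untested is made for them only; others in the source may bear on it.

All three measured compounds share one core, and in a functional assay on MDA-MB-231 cells (Homo sapiens) for antiproliferative activity, read by MTT assay, with a stated time of 24 h (a lower number here means a stronger inhibitor, a higher number a weaker inhibitor), they sit close together. Compound 1 `COc1cc(C(=O)/C=C/c2cc(-c3cc(OC)c(OC)c(OC)c3)n3nc(-c4ccccc4)cc3n2)cc(OC)c1OC` gives 24300 nM. Compound 2 `COc1ccc(/C=C/C(=O)c2cc(-c3ccc(OC)c(OC)c3)n3nc(-c4ccccc4)cc3n2)cc1` gives 22000 nM, the second highest of the three numbers; its nearest neighbour is compound 1, and the gap between the two is within the scatter of the method. Compound 3 `COc1cc(-c2cc(C(=O)/C=C/c3ccccc3)nc3cc(-c4ccccc4)nn23)cc(OC)c1OC` gives 19200 nM, and its gap to compound 2 is also within the scatter, so none of the three can be called stronger or weaker than another on these numbers.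

Compound 4 `COc1ccc(-c2cc(/C=C/C(=O)c3ccc(C)cc3)nc3cc(-c4ccccc4)nn23)cc1OC` has not yet been measured. It differs from compound 2 in one place: 2-((4-methylphenyl)carbonyl)ethenyl in place of (2-(4-methoxyphenyl)ethenyl)carbonyl on an aromatic carbon. Within the data shown here, no measured pair shows exactly this change, so the expectation rests on the narrow spread of the three numbers and on compound 3, whose 2-((phenyl)carbonyl)ethenyl chain gives 19200 nM. The step from compound 2 to compound 4 is expected to be small, a 1.1-fold lower number from compound 2 to compound 4 (0.04 log units; within the scatter), not clearly beyond the scatter in either direction. Compound 4 is therefore estimated at 20000 nM, with a range from 8000 nM to 50000 nM.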

Compound 4, half-maximal inhibitory concentration: 19800 nM
Beside the measured number, compound 4's estimate is 1.0-fold (0.00 log units) above it; the measured number falls inside the stated range.
By their numbers in this assay, from the lowest: compounds 3, 4, 2 and 1 (each within the scatter of the next).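

In this assay the change produces a 1.1-fold lower number from compound 2 to compound 4 (0.05 log units; within the scatter) on the aromatic carbon meta to a 3,4-dimethoxyphenyl group. Among these compounds, this is the first pair differing in one place, and it shows that this position takes 2-((4-methylphenyl)carbonyl)ethenyl as well as (2-(4-methoxyphenyl)ethenyl)carbonyl without a readable shift, even though the carbonyl and the ethenyl swap order and the terminal ring's substituent changes in the same step. Nothing measured here bears on why the step is so small.

The pair cannot separate the swapped order of carbonyl and ethenyl from the change of methoxy to methyl on the terminal ring. It also leaves open whether an amine or a carboxylic acid on that ring, or a longer chain in place of the ethenyl link, would move the number beyond the scatter.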